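The source may hold more compounds than are shown below. What is called first, only, known or untested is meant among the compounds shown, and "the series" means these compounds.

Compound 1 `CCOC(=O)C1=C(NN=C(C(C)=O)C(C)=O)Nc2[nH]nc(C)c2C1c1ccc(N(C)C)cc1`: 8480 nM
Compound 2 `CCOC(=O)C1=C(N/N=C(\c2ccc([N+](=O)[O-])cc2)N2CCN(c3ccc(F)cc3)CC2)Nc2[nH]nc(C)c2C1c1ccc(N(C)C)cc1`: 90200 nM
Compound 3 `CCOC(=O)C1=C(N/C=N/c2nnc(S(N)(=O)=O)s2)Nc2[nH]nc(C)c2C1c1ccc(N(C)C)cc1`: 38100 nM

All three numbers come from a functional assay on HepG2 cells (Homo sapiens) for inhibition, read by MTT assay, with a stated time of 48 h; a lower number here means a stronger inhibitor, a higher number a weaker inhibitor. Compound 3, at 38100 nM, sits in the middle of the set, with compound 2 higher and compound 1 lower.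

The untested compound 4 `CCOC(=O)C1=C(N/N=C(/C(=O)Br)c2ccc(Br)cc2)Nc2[nH]nc(C)c2C1c1ccc(N(C)C)cc1` keeps the shared core and differs from compound 3 only on an amine nitrogen: a group of 12 heavy atoms (8 carbon, 1 nitrogen, 1 oxygen, 2 bromine; one six-membered aromatic ring of carbon only) in place of a group of 11 heavy atoms (3 carbon, 4 nitrogen, 2 oxygen, 2 sulfur; one five-membered aromatic ring with 3 hetero atoms), on an amine nitrogen. The five-membered aromatic ring with 3 hetero atoms leaves, and a six-membered aromatic ring of carbon only enters.

One measured step changes the group at this place and involves compound 3: a 4.5-fold higher number from compound 1 to compound 3 (0.65 log units; beyond the scatter). That step is modest, and it says little about a swap of one ring-bearing group for another. Compound 2 also carries a six-membered aromatic ring of carbon only in this group, and its value of 90200 nM is the highest of the set. Compound 1, whose group has no ring, gives 8480 nM. These few values point to no clear direction, so the estimate stays close to compound 3 with a wide range.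

The expected change is a 1.3-fold lower number from compound 3 to compound 4 (0.10 log units; within the scatter), which would stay within the usual scatter. For compound 4 the estimated value is 30000 nM, with an expected range from 9000 nM to 95000 nM.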

Compound 4, half-maximal inhibitory concentration: 65000 nM
The estimate for compound 4 lay 2.2-fold (0.34 log units) below the measured number; low and high end bracket the measured number.
By their numbers in this assay, from the lowest: compound 1; then compounds 3, 4 and 2 (each within the scatter of the next, the first and the last beyond it).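

In this assay, replacing the group with a five-membered aromatic ring with 3 hetero atoms by one with a six-membered aromatic ring of carbon only gives a 1.7-fold higher number from compound 3 to compound 4 (0.23 log units; within the scatter), so these two quite different ring-bearing groups on the amine nitrogen cannot be told apart here. Compared with the ring-free group of compound 1, the new group gives a 7.7-fold higher number from compound 1 to compound 4 (0.88 log units; beyond the scatter), so compound 4 joins compounds 2 and 3 as a ring-bearing compound with a higher number than compound 1, and no compound shown goes against this pattern. No measurement shown accounts for these differences.

As far as these compounds go, the pattern rests on a single ring-free compound, so it remains open whether the absence of a ring matters at all or whether something else about the group in compound 1 sets it apart. A plain ethyl group, a short amine chain or a carboxylic acid on this amine nitrogen would help separate these possibilities, as would a six-membered aromatic ring of carbon only without the bromine atoms.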